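A Ring Swap on the Chain of Compound 2

The source may report more compounds than this note shows. Statements on the series, on what has been measured and on what is new or still open speak of the compounds shown alone.

In a functional assay on SK-BR-3 cells (Homo sapiens) for antiproliferative activity (a higher number here means a weaker inhibitor, a lower number a stronger inhibitor), compound 2 `CC(C)=CCc1cc(C(=O)Nc2cc3ccc(OCCC4CCCCN4)c(C)c3oc2=O)ccc1O` gives 640 nM and compound 1 `CC(=O)Oc1ccc(C(=O)Nc2cc3ccc(OCC4CCN(C)C4)c(C)c3oc2=O)cc1CC=C(C)C` gives 880 nM, two values within the scatter of each other. Going by the values given here, these compounds differ in more than one place, so no measured step isolates a single change. Compound 3 `CC(C)=CCc1cc(C(=O)Nc2cc3ccc(OCCCN4CCCC4)c(C)c3oc2=O)ccc1O` has the same atoms as compound 2, joined differently: (pyrrolidin-1-yl)methyl in place of piperidin-2-yl on a saturated chain carbon, two bonds along the chain from an oxygen on an aromatic ring. Here (pyrrolidin-1-yl)methyl stands in place of piperidin-2-yl on a saturated chain carbon, two bonds along the chain from an oxygen on an aromatic ring, turning 2-(piperidin-2-yl)ethoxy into 3-(pyrrolidin-1-yl)propoxy. Compound 1 gives 880 nM despite differing from compound 2 in several places, and the two values lie within the scatter of each other, so no step beyond the scatter is expected in this assay, in either direction. The expected change, a 1.1-fold lower number from compound 2 to compound 3 (0.03 log units; within the scatter), is small. For compound 3 the estimated value is 600 nM, with a range of 250 nM to 1500 nM.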

Compound 3, half-maximal inhibitory concentration: 720 nM
For compound 3 the middle estimate is 1.2-fold (0.08 log units) below the measured one; low and high end bracket the measured number.
By their numbers in this assay, from the lowest: compounds 2, 3 and 1 (each within the scatter of the next).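

Putting (pyrrolidin-1-yl)methyl in place of piperidin-2-yl on a saturated chain carbon, two bonds along the chain from an oxygen on an aromatic ring, gives a 1.1-fold higher number from compound 2 to compound 3 (0.05 log units; within the scatter) in this assay. Going by these compounds alone, this is the first measured single change at this place, and it shows that a six-membered ring with a hydrogen-bond donor can give way to a five-membered ring with none, at equal heavy-atom count, without a step beyond the scatter. No measurement shown here bears on the reason for this result.

From the compounds shown here alone, whether a morpholine ring or a longer chain ending in pyrrolidine would also stay within the scatter of compound 2 remains open. Compound 1 still differs from compound 2 in several places, so its acetyl ester and its chain cannot be judged separately.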